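The source may report more compounds than this note shows. Statements on the series, on what has been measured and on what is new or still open speak of the compounds shown alone.

Working notes on the series. Within the data shown here, compound 2 `COc1cc(/C=C/C2CC=CC(=O)N2)cc(OC)c1` stands with the highest number of the two so far: in a functional assay on OVCAR-3 cells (Homo sapiens) for inhibition, read by sulforhodamine B assay, with a stated time of 48 h (a lower number here means a stronger inhibitor of growth, a higher number a weaker inhibitor of growth), compound 2 gives 232 uM. Among the measured compounds shown here, the only neighbour is compound 1 `COc1cc(/C=C/C2CC=CC(=O)O2)cc(OC)c1OC`, which differs in more than one place; in this assay compound 1 gives 44.9 uM, a number well below that of compound 2 and beyond the scatter. Compound 3 `COc1cc(/C=C/C2CC=CC(=O)N2)cc(OC)c1OC` follows from compound 2 by one change: methoxy in place of hydrogen on an aromatic carbon. For the measured compounds named here, no measured pair shows this change alone, so its size is not known from the data. The entering methoxy is present in compound 1, whose value of 44.9 uM is the only hint, and it points to a lower number for compound 3. The step from compound 2 to compound 3 is therefore expected to be downward, a 1.9-fold lower number from compound 2 to compound 3 (0.29 log units; within the scatter), but of uncertain size. Compound 3 is estimated at 120 uM, within a range from 45 uM to 300 uM.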

Compound 3, concentration for growth inhibition (reported as GI): > 864 uM
Compound 3 gave a limit, no number; the forecaster's own chance of this, stated with the estimate: 10%; at least 7.2-fold (0.85 log units) between middle value and limit.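

The result for compound 3 in this assay is a limit and not a number: the limit of > 864 uM in this assay, at which 1 of the 3 values shown sits. Among these compounds, on the aromatic carbon ortho to two methoxy groups and para to a group of 9 heavy atoms, methoxy in place of hydrogen gives an at least 3.7-fold higher number from compound 2 to compound 3 (0.57 log units; beyond the scatter) and so goes with weaker growth inhibition, a direction that the earlier compounds could not show. With this methoxy present in both compounds, exchanging the group of 7 heavy atoms with 2 oxygen for the one with nitrogen and oxygen gives an at least 19-fold higher number from compound 1 to compound 3 (1.28 log units; beyond the scatter), so the lower number of compound 1 does not carry over to the nitrogen-containing group.

The limit leaves the full size of both steps open. Also open, from the compounds shown here alone, is how hydroxyl or ethoxy on the same aromatic carbon would compare with hydrogen and methoxy.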